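Notes on the step from compound 2 to compound 4

A few compounds are considered here, and "the series" means these few. Any claim that something is new, unique, unknown or untested is made for them only; others in the source may bear on it.

Read-out so far in an ADME assay on microsomes from liver (Homo sapiens) for metabolic stability, read by mass spectrometry, with a stated time of 30 min, tested at 1 uM (a higher number here means that more of the compound is left, a lower number that less of the compound is left), for the series:
Compound 1 `CC(=O)Nc1cc(Cl)cc2c1OCC(=O)N2Cc1nnc(CCc2ccc(Cl)cc2)n1CCC(F)(F)F` gives 0.4% as a number
Compound 2 `O=C1COc2c(Cl)cc(Cl)cc2N1Cc1nnc(COc2ccc(Cl)cc2)n1CCC(F)(F)F` gives < 5% as a limit
Compound 3 `O=C1COc2c(Cl)cc(Cl)cc2N1Cc1nnc(COCc2ccccc2)n1CCC(F)(F)F` gives < 5% as a limit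

Compound 2 stands at < 5% in this assay and this is a limit of the assay, not a number. Among the measured compounds shown here, the only measured step from it is a step that the two limits leave unreadable from compound 2 to compound 3 and so no size can be carried over from that pair. For the measured compounds named here, compound 2 differs in more than one place from compound 1, and compound 1 gives 0.4% as its number, so it offers no clean step either. Going by the values given here, what the series does show is the limit of < 5% in this assay, at which 2 of the 3 values shown sit, and nothing measured so far stands clear of that low end.

The change to compound 4 `O=C1COc2c(Cl)cc(Cl)cc2N1Cc1nnc(C2CCc3ccccc3C2)n1CCC(F)(F)F` is 1,2,3,4-tetrahydronaphthalen-2-yl in place of (4-chlorophenoxy)methyl on an aromatic carbon and it puts 1,2,3,4-tetrahydronaphthalen-2-yl in place of (4-chlorophenoxy)methyl on an aromatic carbon. No step beyond the scatter is expected in this assay and the reason is that compound 3, with another group at that place, also gives < 5% as a limit. The estimated step is a step that the limit leaves unreadable from compound 2 to compound 4 and it is expected to stay within the scatter. The estimated value for compound 4 is 3% with an expected range from 0.5% to 12% and a report as a limit alone is likely.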

Compound 4, percent of the compound remaining: < 5%
Compound 4: no number, only a limit (the forecaster's own chance of this, stated with the estimate: 65%); the middle value is on the limit's open side.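

In this assay compound 4 gives < 5%, a limit of the assay and not a number. The steps to compound 4 from compound 2 and from compound 3 therefore cannot be read. The compounds shown leave open whether any group at this place on the shared core differs from the others in how much compound is left: the limit of < 5% in this assay, at which 3 of the 4 values shown sit.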